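Amide nitrogen substituent swap in the catechol ether series

This account rests on a few compounds, and the source may have more. Where it says the series, first, only, none or still open, it means among the compounds named here.

Two compounds of the series have numbers in an assay on isolated protein for inhibition of phosphodiesterase 4A (Sus scrofa); a higher number here means a weaker inhibitor, a lower number a stronger inhibitor. Compound 1 `COc1ccc(C(=O)Nc2ccccc2C(=O)c2ccccc2)cc1OC1CCCC1` gives 1700 nM in this assay. Compound 2 `COc1ccc(C(=O)Nc2ccccc2O)cc1OC1CCCC1` gives 1300 nM in this assay. Going by the values given here, the one step between them, a 1.3-fold lower number from compound 1 to compound 2 (0.12 log units; within the scatter), falls within the scatter, so compound 2 and compound 1 stand together, and no ordering between them can be read from these two numbers.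

Compound 3 `COc1ccc(C(=O)NC2(C)C=C(C)ON2)cc1OC1CCCC1` differs from compound 2 by a group of 7 heavy atoms (5 carbon, 1 nitrogen, 1 oxygen; one five-membered non-aromatic ring with 2 hetero atoms) in place of a group of 7 heavy atoms (6 carbon, 1 oxygen; one six-membered aromatic ring of carbon only), on an amide-type nitrogen. The measured step concerns a substituent on the aromatic ring attached to the amide nitrogen and leaves that ring in place; the change to compound 3 removes the ring itself. Among the compounds with values here, no measured step therefore bears on it, and the single step on record, a 1.3-fold lower number from compound 1 to compound 2 (0.12 log units; within the scatter), only shows that a change on that ring left the number within the scatter.

Within the data shown here, with no comparable step to draw on, the estimate for compound 3 in this assay is set near compound 2, at 3000 nM, with a wide range from 600 nM to 15000 nM; the expected step of a 2.3-fold higher number from compound 2 to compound 3 (0.36 log units; beyond the scatter) is not expected to exceed the scatter in either direction with any confidence.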

Compound 3, half-maximal inhibitory concentration: 450 nM
Compound 3: middle estimate off by 6.7-fold (0.82 log units), on the high side; the whole stated range lies above it.
By their numbers in this assay, from the lowest: compound 3; then compounds 2 and 1 (each within the scatter of the next).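

Placed on an amide-type nitrogen, the 2-hydroxyphenyl group can give way to a five-membered non-aromatic ring with 2 hetero atoms without a loss in this assay: the change gives a 2.9-fold lower number from compound 2 to compound 3 (0.46 log units; beyond the scatter), a modest gain for a group of the same heavy-atom count. Going by these compounds alone, the earlier step, a 1.3-fold lower number from compound 1 to compound 2 (0.12 log units; within the scatter), stayed within the scatter and left the aromatic ring in place, so this is the first change to move the number beyond the scatter, and it does so by replacing the ring itself. No data on hand account for the step.

On these data alone, whether the gain depends on the ring hetero atoms, the double bond or simply the loss of the aromatic ring remains open, and a cyclohexyl or tert-butyl group on the amide-type nitrogen would help separate these. Also open, as far as these compounds go, is whether the gain carries over when the cyclopentyloxy group of the shared core is replaced, for example by a cyclopropylmethoxy group.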